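Extending the Amine Chain: From Compound 2 to Compound 3

A few compounds are considered here, and "the series" means these few. Any claim that something is new, unique, unknown or untested is made for them only; others in the source may bear on it.

Measured compounds:
compound 1, `CCCNC(=S)NCCC(O)c1cc(OC)ccc1N` — 25.4%
compound 2, `CNC(=S)NCCC(O)c1cc(Cl)ccc1N` — 22.1%

Of the compounds shown here, two have been measured in an assay for inhibition of Nitric oxide synthase, inducible (Homo sapiens), read by scintillation counting, with a stated time of 30 min, tested at 1 mM; on this read-out higher numbers stand for more inhibition at the one concentration tested (going by the name of the read-out) and lower numbers for less inhibition. Compound 1 `CCCNC(=S)NCCC(O)c1cc(OC)ccc1N` gives 25.4%, and compound 2 `CNC(=S)NCCC(O)c1cc(Cl)ccc1N` gives 22.1%. The two numbers lie within the usual scatter of each other, so nothing separates them on this read-out.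

Compound 3 `CCCNC(=S)NCCC(O)c1cc(Cl)ccc1N` has not yet been measured. It differs from compound 2 in one place: ethyl in place of hydrogen on a saturated chain carbon bound to an amide-type nitrogen. Compound 1 already carries the propylamino end that compound 3 acquires, though on a core bearing methoxy rather than chloro, and in this assay compound 1 gives a number indistinguishable from that of compound 2. Among the measured compounds shown here, no measured pair shares this single change, so the expectation rests on that comparison alone. The step from compound 2 to compound 3 is expected to be a number 2.9 percentage points higher from compound 2 to compound 3 (within the scatter), a shift that stays within the scatter. Compound 3 is therefore expected to give about 25%, within a range from 10% to 40%.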

Compound 3, a percentage reported as inhibition, at one concentration (the size of the read-out at that concentration, not a potency): 55%
Estimate against measurement, compound 3: 30 percentage points below; the measured number lies above the stated range.
By their numbers in this assay, from the lowest: compounds 2 and 1 (each within the scatter of the next); then compound 3.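

In this assay, with the chloro core held fixed, propylamino in place of methylamino is a large change (a number 32.9 percentage points higher from compound 2 to compound 3 (beyond the scatter)), which shows that this saturated chain end can move the read-out well beyond the scatter. With the propylamino end held fixed, chloro in place of methoxy on an aromatic carbon also matters (a number 29.6 percentage points higher from compound 1 to compound 3 (beyond the scatter)), something the two earlier numbers, lying within the scatter of each other, gave no hint of. Nothing available here accounts for either step.

The compounds shown hold only methyl and propyl at this chain end, so they leave open whether a butyl or longer chain would raise the number further or lower it. They also leave open how bromo or fluoro on that aromatic carbon would compare with chloro.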